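Cyclopropyl to 2,4-difluorophenyl on the oxygen

This account rests on a few compounds, and the source may have more. Where it says the series, first, only, none or still open, it means among the compounds named here.

- Compound 1 `Cc1cc(F)cc(C)c1Oc1ccc(C(C)(C)O)cc1-c1cn(C)c(=O)c2[nH]c(C(=O)NCCCCCCC(=O)NO)cc12`: 300 nM
- Compound 2 `Cn1cc(-c2cc(C(C)(C)O)ccc2OC2CC2)c2cc(C(=O)NCCCCCCC(=O)NO)[nH]c2c1=O`: 220 nM

Going by the values given here, in a functional assay on MV4-11 cells (Homo sapiens) for antiproliferative activity, read by CCK-8 assay, with a stated time of 72 h (a lower number here means a stronger inhibitor, a higher number a weaker inhibitor), compound 2 gives 220 nM, which cannot be separated from compound 1, the only other measured compound. The next structure is compound 3 `Cn1cc(-c2cc(C(C)(C)O)ccc2Oc2ccc(F)cc2F)c2cc(C(=O)NCCCCCCC(=O)NO)[nH]c2c1=O`, with 2,4-difluorophenyl in place of cyclopropyl on an oxygen on an aromatic ring. Among the compounds with values here, the one measured step bearing on this is a 1.4-fold lower number from compound 1 to compound 2 (0.13 log units; within the scatter), which exchanged 4-fluoro-2,6-dimethylphenyl and cyclopropyl on that same oxygen. Within the data shown here, with only that step as a guide, no change beyond the scatter is expected. The estimated step is a 1.1-fold higher number from compound 2 to compound 3 (0.06 log units; within the scatter). The expected value for compound 3 is 250 nM, with an estimated range of 110 nM to 550 nM.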

Compound 3, half-maximal inhibitory concentration: 250 nM
Compound 3: the middle estimate sits on the measured number at the digits printed; low and high end bracket the measured number.
By their numbers in this assay, from the lowest: compounds 2, 3 and 1 (each within the scatter of the next).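

With a 1.1-fold higher number from compound 2 to compound 3 (0.06 log units; within the scatter) in this assay the cyclopropyl and 2,4-difluorophenyl groups cannot be told apart on this oxygen, although 3 and 8 heavy atoms are exchanged. With a 1.2-fold lower number from compound 1 to compound 3 (0.08 log units; within the scatter) the 2,4-difluorophenyl and 4-fluoro-2,6-dimethylphenyl groups cannot be told apart either, so all three groups on this oxygen lie within the scatter of one another. No data at hand explain this lack of separation.

Open, going by these compounds, is whether this flat picture holds for groups of another kind on the same oxygen, such as an amine, a carboxylic acid or a longer chain.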